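The compounds below may be only part of what the source reports. "The series", "measured", "known", "first", "only" and "open" are said of these compounds alone.

Compound 2, with the structure `CC1=C(C(=O)OC2CCC2)C(c2ccco2)NC(=O)N1`, is the higher of the two compounds measured in an assay on membranes from CHO cells for displacement of a labelled ligand from adenosine receptor A1 (Homo sapiens), read by scintillation counting, with a stated time of 60 min, tested at 1 uM; on this read-out higher numbers stand for more inhibition at the one concentration tested (going by the name of the read-out) and lower numbers for less inhibition: compound 2 gives 19%, while compound 1, with the structure `CC1=C(C(=O)NC(C)C)C(c2ccco2)NC(=O)N1`, gives 3%. For the measured compounds named here, the single measured step, a number 16 percentage points higher from compound 1 to compound 2 (beyond the scatter), comes from replacing isopropylamino by cyclobutyloxy on a carbonyl carbon. Compound 3, with the structure `CC1=C(C(=O)OC2CCCC2)C(c2ccco2)NC(=O)N1`, has not been measured; it differs from compound 2 in one place: cyclopentyl in place of cyclobutyl on an oxygen next to a carbonyl group. Going by the values given here, no measured step concerns a change of ring size on this oxygen; the only step seen swaps an amine for an ester and does not bear directly on it. The expectation for compound 3 is therefore a step of a number 3 percentage points higher from compound 2 to compound 3 (within the scatter) that stays within the scatter. Compound 3 is thus estimated to give 22% in this assay, within a range from 8% to 40%.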

Compound 3, a percentage reported as inhibition, at one concentration (the size of the read-out at that concentration, not a potency): 1%
Compound 3: middle estimate off by 21 percentage points, on the high side; the measured number lies below the stated range.
By their numbers in this assay, from the lowest: compounds 3 and 1 (each within the scatter of the next); then compound 2.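

In this assay, for the compounds shown here, the group on this ester oxygen matters more than the earlier compounds could show: changing cyclobutyl to cyclopentyl gives a number 18 percentage points lower from compound 2 to compound 3 (beyond the scatter) and cancels the gain seen with compound 2. Replacing isopropylamino with cyclopentyloxy gives a number 2 percentage points lower from compound 1 to compound 3 (within the scatter), so among these compounds an ester in place of the amide does not by itself give a higher number, and compound 2 alone stands apart. Nothing available here explains why this small change in ring size has such an effect.

From the compounds shown here alone, it remains open whether a smaller ring such as cyclopropyl or a larger one such as cyclohexyl would give a higher or lower number. Going by these compounds, the effect of an open chain such as n-butyl on the same oxygen also remains open.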